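The source may report more compounds than this note shows. Statements on the series, on what has been measured and on what is new or still open speak of the compounds shown alone.

Measured compounds:
compound 1 `CCN(CC)c1ccc2cc(C(=O)c3ccc(N4CCN(C(=O)COc5ccc(Cl)cc5Cl)CC4)cc3)oc2c1`, 5730 nM
compound 2 `CCN(CC)c1ccc2cc(C(=O)c3ccc(N4CCN(S(=O)(=O)c5ccc(Br)cc5)CC4)cc3)oc2c1`, 34300 nM

Compound 2 stands at the highest of the two numbers recorded in a functional assay on A549 cells (Homo sapiens) for cytotoxicity, read by MTT assay, with a stated time of 48 h; on this read-out lower numbers stand for stronger inhibition and higher numbers for weaker inhibition; its nearest neighbour is compound 1, which gives 5730 nM. Within the data shown here, the only step available within these two compounds is a 6.0-fold higher number from compound 1 to compound 2 (0.78 log units; beyond the scatter), and it concerns the group on the amine nitrogen in the ring, not the substituent on the aryl ring of the sulfonyl group.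

The unmeasured compound 3 `CCN(CC)c1ccc2cc(C(=O)c3ccc(N4CCN(S(=O)(=O)c5ccc([N+](=O)[O-])cc5)CC4)cc3)oc2c1` keeps the whole of compound 2 apart from one change: nitro in place of bromo on an aromatic carbon of a six-membered aromatic ring of carbon only. Among the measured compounds shown here, no measured step touches this position, so the one step known, from compound 1 to compound 2, gives no direction for it; it only shows that changes at the amine nitrogen can move this assay modestly. With nothing to point either way, compound 3 is expected to stay close to compound 2, with a step of a 1.1-fold lower number from compound 2 to compound 3 (0.06 log units; within the scatter) that is not expected to pass beyond the scatter. The estimate for compound 3 in this assay is therefore 30000 nM, within a range from 10000 nM to 90000 nM.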

Compound 3, half-maximal inhibitory concentration: 24400 nM
Compound 3: middle estimate off by 1.2-fold (0.09 log units), on the high side, and the stated range covers the measured number.
By their numbers in this assay, from the lowest: compound 1; then compounds 3 and 2 (each within the scatter of the next).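

In this assay the change on the aromatic carbon para to a large group gives a 1.4-fold lower number from compound 2 to compound 3 (0.15 log units; within the scatter) and so shows that, for this pair, nitro in place of bromo leaves the number within the scatter, even though nitro brings hydrogen-bond acceptors that bromo lacks. The comparison at the amine nitrogen now has a second sulfonyl compound, with a 4.3-fold higher number from compound 1 to compound 3 (0.63 log units; beyond the scatter) and thus a modest step in the same direction as the one seen with the (4-bromophenyl)sulfonyl group, so among these three compounds the group on that nitrogen moves the number beyond the scatter while the exchange on the aromatic ring does not. No measurement on hand gives a reason for either result.

As far as these compounds go, whether an amine or a carboxylic acid at this aromatic position would also stay within the scatter of bromo and nitro remains open. From the compounds shown here alone, it is equally open whether a longer chain between the carbonyl and the 2,4-dichlorophenoxy group on the amine nitrogen would take the number lower than compound 1 gives.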